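The compounds below may be only part of what the source reports. "The series", "measured", "known", "first", "only" and "open" are said of these compounds alone.

Working notes on the series. In a functional assay on MCF7 cells (Homo sapiens) for antiproliferative activity, read by MTT assay, with a stated time of 72 h (a higher number here means a weaker inhibitor, a lower number a stronger inhibitor), compound 1 (`CCCSc1nc(N/N=C(\C)c2ccc(OC)cc2)c2nnn(Cc3ccccc3)c2n1`) gives > 64000 nM, which is a limit and not a number. Compound 2 (`CCCSc1nc(N/N=C/c2cc(OC)c(OC)c(OC)c2)c2nnn(Cc3ccccc3)c2n1`) gives > 64000 nM, also a limit. Compound 3 (`CCCSc1nc(N/N=C(\C)c2ccccc2O)c2nnn(Cc3ccc(F)cc3)c2n1`) gives > 64000 nM, again a limit. The whole measured set therefore comes down to one entry: the limit of > 64000 nM in this assay, at which 3 of the 3 values shown sit. Going by the values given here, compound 1 stands at that limit, and no measured pair shows the size of a single structural step.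

Compound 4 (`CCCSc1nc(N/N=C(\C)c2ccc(Br)cc2)c2nnn(Cc3ccccc3)c2n1`) keeps the core of compound 1 and changes one substituent: bromo in place of methoxy on an aromatic carbon. This is bromo in place of methoxy on an aromatic carbon, para to a large group, so 4-methoxyphenyl becomes 4-bromophenyl.

With compound 1 at > 64000 nM, a limit, no step beyond the scatter is expected in this assay, and any movement that does appear would be toward a stronger inhibitor. The expected change is a number no higher from compound 1 to compound 4 (the limit leaves the size open). For compound 4 the estimate is 64000 nM, with an expected range from 20000 nM to 120000 nM, and a report as a limit alone is the likeliest outcome.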

Compound 4, half-maximal inhibitory concentration: 13000 nM
Beside the measured number, compound 4's estimate is 4.9-fold (0.69 log units) above it, and the stated range ends above it.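

Going by these compounds alone, the change from 4-methoxyphenyl to 4-bromophenyl gives an at least 4.9-fold lower number from compound 1 to compound 4 (0.69 log units; beyond the scatter) in this assay and is the first single step that can be read. Compound 1 carries only a limit, so this step sets a lower bound on the size of the change and does not fix its full size. The substituent on the aromatic carbon para to a large group can therefore move the read-out off the limit with the rest of the structure held constant, and compound 4 is the only compound shown that gives a number rather than a limit: the limit of > 64000 nM in this assay, at which 3 of the 4 values shown sit.

One pair cannot show whether this shift is specific to bromo or would also appear with another group at the same place, such as chloro, methyl, trifluoromethyl or an amine. It also leaves open whether bromo would bring the same shift with a change elsewhere on the core of compound 1, such as a longer chain in place of the propylthio group or another group in place of benzyl.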